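From 3,4-dichlorophenyl to pyridin-3-yl on a shared core

A few compounds are considered here, and "the series" means these few. Any claim that something is new, unique, unknown or untested is made for them only; others in the source may bear on it.

Compound 1 `CCOc1ccc(/C=C/C(=O)c2ccc3c(c2O)C=CC(C)(C)O3)cc1` gives 215000 nM
Compound 2 `CC1(C)C=Cc2c(ccc(C(=O)/C=C/c3ccc(Cl)c(Cl)c3)c2O)O1` gives 142000 nM
Compound 3 `CC1(C)C=Cc2c(ccc(C(=O)/C=C/c3cccnc3)c2O)O1` has not yet been measured

In an ADME assay on Vero cells (Chlorocebus sabaeus) for cytotoxicity, read by MTT assay, with a stated time of 72 h (a lower number here means that less compound is tolerated, a higher number that more compound is tolerated), compound 2 gives 142000 nM and compound 1 gives 215000 nM, so the two values lie within the usual scatter of each other. The step to compound 3 puts pyridin-3-yl in place of 3,4-dichlorophenyl on a double-bonded chain carbon bound to a double-bonded chain carbon. Among the measured compounds shown here, no measured pair in this small set differs in one place only, so no direct precedent exists for the size of this step. In this assay no change beyond the scatter is expected, and no firm direction can be assigned. The estimated change is a 1.3-fold higher number from compound 2 to compound 3 (0.13 log units; within the scatter), which remains a tentative expectation. Compound 3 is expected to give 190000 nM, with an estimated range from 85000 nM to 420000 nM.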

Compound 3, half-maximal cytotoxic concentration: 8600 nM
The estimate for compound 3 lay 22-fold (1.34 log units) above the measured number, and the stated range ends above it.
By their numbers in this assay, from the lowest: compound 3; then compounds 2 and 1 (each within the scatter of the next).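

In this assay, replacing 3,4-dichlorophenyl with pyridin-3-yl on the double-bonded chain carbon gives a 17-fold lower number from compound 2 to compound 3 (1.22 log units; beyond the scatter), so this position can carry a large change in the number on the shared core. The earlier compounds shown here could not show this, as compounds 1 and 2 lie within the scatter of each other and offered no step between measured compounds. Nothing measured here accounts for the size of this step.

The step takes away both chlorine atoms and brings in a ring nitrogen at once, so the compounds shown do not separate these two parts of the change. From the compounds shown here alone, it remains open where an unsubstituted phenyl, a 3-chlorophenyl or a pyridin-4-yl group at this place would fall in this assay.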